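Weak Cytotoxins on a Shared Core: A Thioether Variant

The source may hold more compounds than are shown below. What is called first, only, known or untested is meant among the compounds shown, and "the series" means these compounds.

The study starts from compound 1 `Nc1cc(N)c2nc(-c3ccccc3)c(Oc3ccc(Cl)c(Cl)c3)nc2c1`. In a functional assay on NCI-H23 cells (Homo sapiens) for inhibition, read by sulforhodamine B assay, with a stated time of 48 h (on this read-out lower numbers stand for higher toxicity in this test and higher numbers for lower toxicity in this test), compound 1 gives only a limit, < 100000 nM, and not a number. Two further compounds on the same core carry numbers in this assay : compound 2 `Nc1cc(N)c2nc(-c3ccccc3)c(NCc3ccc(Cl)c(Cl)c3)nc2c1` gives 55000 nM, and compound 3 `CCOC(=O)[C@H](CCC(=O)O)NC(=O)c1ccc(Sc2nc3cc(N)cc(N)c3nc2-c2ccccc2)cc1` gives 95500 nM. All three sit at the weak end of the scale, and compound 1 stands at the limit of < 100000 nM in this assay, at which 1 of the 3 values shown sits, so its position relative to compound 2 and compound 3 cannot be fixed.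

The unmeasured compound 4 `Nc1cc(N)c2nc(-c3ccccc3)c(Sc3ccc(F)cc3)nc2c1` differs from compound 1 by (4-fluorophenyl)sulfanyl in place of 3,4-dichlorophenoxy on an aromatic carbon. Going by the values given here, no measured pair shows such a change, and the two compounds with numbers lie close to the limit of compound 1. The author therefore expects the step that the limit leaves unreadable from compound 1 to compound 4 to be small, with no direction beyond the scatter, and expects compound 4 to give about 60000 nM in this assay , within 20000 nM to 100000 nM.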

Compound 4, concentration lethal to 50% of the cells: 81300 nM
Estimate against measurement, compound 4: 1.4-fold (0.13 log units) below; measured number inside the range.
By their numbers in this assay, from the lowest: compounds 2, 4 and 3 (each within the scatter of the next).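

No step can be read from compound 1 to compound 4, because compound 1 carries a limit and not a number: the limit of < 100000 nM in this assay, at which 1 of the 4 values shown sits.

The compounds shown leave open how (4-fluorophenyl)sulfanyl and 3,4-dichlorophenoxy compare with each other on the shared core.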